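A few compounds are considered here, and "the series" means these few. Any claim that something is new, unique, unknown or untested is made for them only; others in the source may bear on it.

Going by the values given here, compound 1 `FC(F)(F)c1ccc(C2CC(c3ccc(Cl)cc3)=NN2c2ccc(-c3ccccc3)nn2)cc1` is the one fully numbered member of the series: in a functional assay on HepG2 cells (Homo sapiens) for antiproliferative activity, read by MTT assay, with a stated time of 24 h (on this read-out higher numbers stand for weaker inhibition and lower numbers for stronger inhibition), compound 1 gives 8330 nM. Compound 2 `COc1ccc(C2CC(c3ccc(Cl)cc3)=NN2c2ccc(-c3ccccc3)nn2)cc1` carries the change (methoxy in place of trifluoromethyl on an aromatic carbon). In this assay compound 2 reaches only a limit of the assay, > 100000 nM. Compound 3 `COc1ccc(C2=NN(c3ccc(-c4ccccc4)nn3)C(c3ccc(C(F)(F)F)cc3)C2)cc1` differs from compound 1 by methoxy in place of chloro on an aromatic carbon. In this assay compound 3 likewise sits at a limit, > 100000 nM. Both steps are large: an at least 12-fold higher number from compound 1 to compound 2 (1.07 log units; beyond the scatter), and an at least 12-fold higher number from compound 1 to compound 3 (1.07 log units; beyond the scatter), each of them bounded by the limit of > 100000 nM in this assay, at which 2 of the 3 values shown sit.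

Compound 4 `COc1ccc(C2=NN(c3ccc(-c4ccccc4)nn3)C(c3ccc(OC)cc3)C2)cc1` is not yet measured. Its difference from compound 3, (methoxy in place of trifluoromethyl on an aromatic carbon), is the same change that was made from compound 1 to compound 2, and the place is the same; the two cores differ as described for compound 3 against compound 1. That earlier change gave a step of an at least 12-fold higher number from compound 1 to compound 2 (1.07 log units; beyond the scatter). Since compound 3 already stands at a limit in this assay, the step that the limit leaves unreadable from compound 3 to compound 4 that is expected cannot be seen as a number and would most likely again end at the limit. Compound 4 is therefore estimated at 300000 nM, between 100000 nM and 2000000 nM, with a limit the most probable outcome.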

Compound 4, half-maximal inhibitory concentration: > 100000 nM
Compound 4: no number, only a limit; the forecaster's own chance of this, stated with the estimate: 90%; the middle value lies beyond the limit too.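

In this assay compound 4 gives > 100000 nM, a limit and not a number. Neither the step from compound 3 to compound 4 nor that from compound 2 to compound 4 can be read, because the values end at a limit: the limit of > 100000 nM in this assay, at which 3 of the 4 values shown sit.

The compounds shown leave open whether methoxy in place of trifluoromethyl changes compound 3 as much as compound 1.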